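Urea aryl swap in the thienopyrimidine urea series

This account rests on a few compounds, and the source may have more. Where it says the series, first, only, none or still open, it means among the compounds named here.

Compound 3 `CCN(CC)CCNc1nc(-c2ccc(NC(=O)Nc3ccccc3F)cc2)nc2ccsc12` stands highest of the three numbers in a functional assay on MKN-45 cells (Homo sapiens) for cytotoxicity, read by MTT assay, with a stated time of 72 h; on this read-out lower numbers stand for stronger inhibition and higher numbers for weaker inhibition: compound 3 gives 1040 nM. Going by the values given here, compound 1 `CN(C)CCNc1nc(-c2ccc(NC(=O)Nc3ccc(Cl)cc3)cc2)nc2ccsc12` gives 250 nM and compound 2 `CCN(CC)CCCNc1nc(-c2ccc(NC(=O)Nc3ccc(Cl)cc3)cc2)nc2ccsc12` gives 180 nM; the one measured step, a 1.4-fold lower number from compound 1 to compound 2 (0.14 log units; within the scatter), lies within the scatter, so the amine tail change does not move the read-out. Compound 4 `CCN(CC)CCNc1nc(-c2ccc(NC(=O)Nc3ccc(Cl)cc3)cc2)nc2ccsc12` is the untested member; it differs from compound 3 by 4-chlorophenyl in place of 2-fluorophenyl on an amide-type nitrogen. Among the compounds with values here, no measured pair isolates this change, so no direct step is available. Compound 4 shares its 4-chlorophenyl urea with compound 1 and compound 2 and its (diethylamino)ethyl tail sits between the tails of those two; both carry numbers well below compound 3. The expectation is therefore a drop in this assay of roughly the size seen between compound 3 and compound 1, expressed as a 4.7-fold lower number from compound 3 to compound 4 (0.67 log units; beyond the scatter). Compound 4 is estimated at 220 nM, with a range from 110 nM to 450 nM.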

Compound 4, half-maximal inhibitory concentration: 370 nM
For compound 4 the middle estimate is 1.7-fold (0.23 log units) below the measured one; the measured number falls inside the stated range.
By their numbers in this assay, from the lowest: compounds 2, 1 and 4 (each within the scatter of the next, the first and the last beyond it); then compound 3.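

Read in this assay the change to 4-chlorophenyl in place of 2-fluorophenyl on an amide-type nitrogen now has a direct step (a 2.8-fold lower number from compound 3 to compound 4 (0.45 log units; beyond the scatter)), so this position does respond to the aryl group, though modestly. With the 4-chlorophenyl held, the amine tail changes read (a 1.5-fold higher number from compound 1 to compound 4 (0.17 log units; within the scatter)) and (a 2.1-fold higher number from compound 2 to compound 4 (0.31 log units; beyond the scatter)): the first sits within the scatter, the second only just beyond it, a modest step. Nothing on hand bears on what lies behind the aryl step.

The swap changes the halogen and its place on the ring together, so neither can be credited alone. A 4-fluorophenyl or 2-chlorophenyl on the same nitrogen, with the (diethylamino)ethyl tail kept, would separate the two, and a 4-methoxyphenyl would test whether a halogen is needed at all.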